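Methoxy added to the benzyl of compound 1

The compounds below may be only part of what the source reports. "The series", "measured", "known", "first", "only" and "open" are said of these compounds alone.

Compound 1 `COc1ccc2[nH]c(C(=O)N3CC(=O)N(Cc4ccccc4)[C@@H](CCc4ccccc4)C3)cc2c1` has been tested in an ADME assay on Vero cells (Chlorocebus sabaeus) for cytotoxicity, with a stated time of 7 days; on this read-out lower numbers stand for higher toxicity in this test and higher numbers for lower toxicity in this test. In this assay compound 1 reaches only a limit, > 30000 nM. Compound 2 `COc1ccc2[nH]c(C(=O)N3CC(=O)N(Cc4ccccc4)[C@@H](COCc4ccccc4)C3)cc2c1` also reaches only a limit in this assay, > 30000 nM. Among the compounds with values here, the step that the two limits leave unreadable from compound 1 to compound 2 is hence of no readable size; the series so far shows (the limit of > 30000 nM in this assay, at which 2 of the 2 values shown sit). Compound 3 `COc1cccc(CN2C(=O)CN(C(=O)c3cc4cc(OC)ccc4[nH]3)C[C@@H]2CCc2ccccc2)c1` differs from compound 1 by methoxy in place of hydrogen on an aromatic carbon. No measured step covers that exchange, and the single step shown gives no size. The step that the limit leaves unreadable from compound 1 to compound 3 is expected to be none readable, staying at the limit. The estimate for compound 3 is 45000 nM, within 15000 nM to 150000 nM.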

Compound 3, half-maximal cytotoxic concentration: 4500 nM
For compound 3 the middle estimate is 10-fold (1.00 log units) above the measured one; measured number outside the range, below it.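

In this assay, compound 3 is the first compound shown with a number instead of a limit: the limit of > 30000 nM in this assay, at which 2 of the 3 values shown sit. 3-Methoxybenzyl in place of benzyl gives an at least 6.6-fold lower number from compound 1 to compound 3 (0.82 log units; beyond the scatter), so the aromatic ring of the benzyl is a place where this read-out responds, towards higher toxicity in this test. The step gives only a lower bound on the size, and the step between the two limits cannot be read.

Still open, from the compounds shown here alone, is whether methoxy at another place on this ring gives the same shift, and whether an amine, a carboxylic acid or a longer alkoxy chain at this place does.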